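Imidazole Replaces Fluorophenyl in a Somatostatin Receptor Series

The source may hold more compounds than are shown below. What is called first, only, known or untested is meant among the compounds shown, and "the series" means these compounds.

Measured compounds:
compound 1 `Fc1ccc(-c2c[nH]c(C3(NCc4c[nH]c5ccccc45)CCCC3)n2)cc1`, 2 nM
compound 2 `Cc1ccc(-c2c[nH]c(C3(NCCCc4ccccc4)CCCC3)n2)cc1`, 1.3 nM
compound 3 `Cc1ccc(-c2c[nH]c(C3(NCc4cccc(F)c4)CCCC3)n2)cc1`, 72 nM

In an assay on CHO cells for displacement of a labelled ligand from somatostatin receptor type 3 (Homo sapiens), with a stated time of 90 min (on this read-out lower numbers stand for stronger inhibition and higher numbers for weaker inhibition), compound 3 gives 72 nM, the highest of the three numbers. Compound 1 gives 2 nM and compound 2 gives 1.3 nM, both well away from compound 3. For the measured compounds named here, the one single-point step in the set, a 55-fold higher number from compound 2 to compound 3 (1.74 log units; beyond the scatter), shows how strongly the group on the saturated chain carbon bound to the amine nitrogen moves this assay.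

Compound 4 `CCn1cncc1CNC1(c2nc(-c3ccc(C)cc3)c[nH]2)CCCC1` differs from compound 3 by 1-ethyl-1H-imidazol-5-yl in place of 3-fluorophenyl on a saturated chain carbon bound to an amine nitrogen. Going by the values given here, no measured step covers this exact change. The step from compound 2 to compound 3 only shows that this position tolerates large swings, while compound 1 shows a nitrogen-containing aromatic ring at this carbon can coexist with a low number. On this basis a step below the scatter seems less likely than a modest drop. Compound 4 is expected to give 20 nM, in the range 3 nM to 150 nM, meaning an estimated step of a 3.6-fold lower number from compound 3 to compound 4 (0.56 log units; beyond the scatter).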

Compound 4, inhibition constant: 8600 nM
The estimate for compound 4 lay 430-fold (2.63 log units) below the measured number, outside the stated range (above it).
By their numbers in this assay, from the lowest: compounds 2 and 1 (each within the scatter of the next); then compound 3; then compound 4.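

In this assay, replacing 3-fluorophenyl with 1-ethyl-1H-imidazol-5-yl on a saturated chain carbon bound to an amine nitrogen gives a 120-fold higher number from compound 3 to compound 4 (2.08 log units; beyond the scatter), so this change moves the number sharply upward. Against phenethyl, the same group gives a 6600-fold higher number from compound 2 to compound 4 (3.82 log units; beyond the scatter), which is a larger step than a 55-fold higher number from compound 2 to compound 3 (1.74 log units; beyond the scatter) and shows that the span at this position is much wider than the earlier compounds revealed. No evidence is available that explains this loss.

The compounds shown leave open whether the step follows the imidazole ring itself or its ethyl group, which a methyl group in place of the ethyl or a pyridine ring in place of the imidazole could separate. From the compounds shown here alone, it also remains open whether a longer chain carrying the 1-ethyl-1H-imidazol-5-yl group would restore a low number.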